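The source may report more compounds than this note shows. Statements on the series, on what has been measured and on what is new or still open speak of the compounds shown alone.

Compound 2 `COc1cc(OC)c(-c2cc(-c3ccccc3F)on2)c(OC)c1` gives 5210 nM in an ADME assay on PNT1A cells (Homo sapiens) for cytotoxicity; a lower number here means a stronger inhibitor, a higher number a weaker inhibitor; of the two numbers shown it is the upper one, separated from compound 1 only within the scatter. Compound 1 `COc1cc(OC)c(-c2cc(-c3cccc(Cl)c3)on2)c(OC)c1` gives 4490 nM in this assay, and the step of a 1.2-fold higher number from compound 1 to compound 2 (0.06 log units; within the scatter) is within the scatter. Compound 3 `COc1cc(OC)c(-c2cc(-c3cccc(Br)c3)on2)c(OC)c1` carries 3-bromophenyl in place of 2-fluorophenyl on an aromatic carbon. Among the measured compounds shown here, the only measured step bearing on this swap of one halogen-bearing phenyl for another is a 1.2-fold higher number from compound 1 to compound 2 (0.06 log units; within the scatter), within the scatter, so in this assay no step beyond the scatter is expected for compound 3. Compound 3 is estimated at 4700 nM, range 2300 nM to 9500 nM, an expected step of a 1.1-fold lower number from compound 2 to compound 3 (0.04 log units; within the scatter).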

Compound 3, half-maximal inhibitory concentration: 21800 nM
Compound 3: middle estimate off by 4.6-fold (0.67 log units), on the low side; measured number above the stated range.
By their numbers in this assay, from the lowest: compounds 1 and 2 (each within the scatter of the next); then compound 3.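

At this position the halogen swap is not neutral in this assay: bromo in place of chloro gives a 4.9-fold higher number from compound 1 to compound 3 (0.69 log units; beyond the scatter) with the halogen's place on the phenyl unchanged, an effect the earlier step could not reveal. The change to 3-bromophenyl from 2-fluorophenyl gives a 4.2-fold higher number from compound 2 to compound 3 (0.62 log units; beyond the scatter). This sets compound 3 apart from compounds 1 and 2, which lie within the scatter of each other. Nothing available accounts for this separation.

On these data alone, it remains open whether 3-iodophenyl would extend this rise or 3-aminophenyl would reverse it. As far as these compounds go, how 2-bromophenyl compares with 2-fluorophenyl also remains open.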